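The source may report more compounds than this note shows. Statements on the series, on what has been measured and on what is new or still open speak of the compounds shown alone.

Compound 1 `COc1ccc2nc(C)cc(NCc3ccccc3)c2c1` gives 25900 nM
Compound 2 `COc1ccc2nc(C)cc(SCc3ccc(F)cc3)c2c1` gives 41000 nM

Both numbers come from a functional assay on MCF-10A cells (Homo sapiens) for antiproliferative activity, with a stated time of 48 h (on this read-out lower numbers stand for an effect already at smaller amounts and higher numbers for an effect only at larger amounts of compound), and lie within the usual scatter of each other. Compound 1 therefore stands level with compound 2 on this evidence, and both need fairly large amounts of compound for an effect to appear.

The next compound, compound 3 `COc1ccc2nc(C)cc(NCc3ccc(C)cc3)c2c1`, keeps the core of compound 1 and makes one small change: methyl in place of hydrogen on an aromatic carbon, so that phenyl becomes 4-methylphenyl (methyl in place of hydrogen on an aromatic carbon). Within the data shown here, no two measured compounds differ in only one place, so the data offer no direct guide to this change. With so small an addition, no shift beyond the scatter is expected in this assay, and the estimated size of the step is small (a 1.0-fold higher number from compound 1 to compound 3 (0.02 log units; within the scatter)). The expected value for compound 3 is 27000 nM with 13000 nM to 55000 nM as its estimated range.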

Compound 3, half-maximal effective concentration: 18800 nM
Compound 3: the middle estimate sits 1.4-fold (0.16 log units) above what was measured, within the range that was stated.
By their numbers in this assay, from the lowest: compounds 3, 1 and 2 (each within the scatter of the next, the first and the last beyond it).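

Among these compounds, this is the first step that changes a single place, the phenyl group of compound 1 becoming 4-methylphenyl, with the methyl para to a large group. In this assay, it gives a 1.4-fold lower number from compound 1 to compound 3 (0.14 log units; within the scatter), so this position can carry a methyl without a shift beyond the scatter, and the compound still needs fairly large amounts for an effect to appear. No measurement is at hand that could explain this step.

A single methyl says little about what larger or different groups would do here. On these data alone, it remains open whether a longer chain, an amine or a carboxylic acid at the same position would move the number beyond the scatter, in either direction.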